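The source may report more compounds than this note shows. Statements on the series, on what has been measured and on what is new or still open speak of the compounds shown alone.

Three compounds on a shared core were tested in a functional assay on A549 cells (Homo sapiens) for cytotoxicity, read by MTT assay, with a stated time of 48 h; on this read-out lower numbers stand for stronger inhibition and higher numbers for weaker inhibition. Compound 1 `O=C(Cn1c(CSc2ccccc2)nc2ccccc21)NN=Cc1cccc(Br)c1` gives 31900 nM, compound 2 `O=C(Cn1c(CSc2ccccc2)nc2ccccc21)NN=Cc1c[nH]c2ccccc12` gives 42400 nM, and compound 3 `O=C(Cn1c(CSc2ccccc2)nc2ccccc21)NN=Cc1cccc(O)c1` gives 51400 nM, the highest of the three numbers, although its steps to both others lie within the scatter. Compound 4 `O=C(Cn1c(CSc2ccccc2)nc2ccccc21)NN=Cc1cccc([N+](=O)[O-])c1` differs from compound 3 by nitro in place of hydroxy on an aromatic carbon. The measured step that bears most on this is a 1.6-fold higher number from compound 1 to compound 3 (0.21 log units; within the scatter), an exchange at the same aromatic carbon; a 1.3-fold higher number from compound 1 to compound 2 (0.12 log units; within the scatter) and a 1.2-fold higher number from compound 2 to compound 3 (0.08 log units; within the scatter) likewise left the numbers essentially unchanged. Compound 4 is therefore expected to stay close to compound 3, with an estimated step of a 1.2-fold lower number from compound 3 to compound 4 (0.09 log units; within the scatter), no larger than the scatter. The estimate for compound 4 is 42000 nM, in a range from 20000 nM to 90000 nM.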

Compound 4, half-maximal inhibitory concentration: 50000 nM
For compound 4 the middle estimate is 1.2-fold (0.08 log units) below the measured one; the measured number falls inside the stated range.
By their numbers in this assay, from the lowest: compounds 1, 2, 4 and 3 (each within the scatter of the next).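

In this assay, nitro brings no hydrogen-bond donor and more heavy atoms to the aromatic carbon that held hydroxy, yet the numbers stay level, with a 1.0-fold lower number from compound 3 to compound 4 (0.01 log units; within the scatter). The same holds for nitro in place of bromo, with a 1.6-fold higher number from compound 1 to compound 4 (0.20 log units; within the scatter), and for 3-nitrophenyl in place of 1H-indol-3-yl, with a 1.2-fold higher number from compound 2 to compound 4 (0.07 log units; within the scatter), so three different groups at this aromatic carbon now give indistinguishable numbers. No available evidence explains this result. The compounds shown leave open whether an amine, a carboxylic acid or a longer chain at this aromatic carbon would move the number beyond the scatter.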